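Thiophen-2-yl in place of 6-methoxypyridin-3-yl: stability notes

The source may hold more compounds than are shown below. What is called first, only, known or untested is meant among the compounds shown, and "the series" means these compounds.

Values in an ADME assay on microsomes from liver (Homo sapiens) for metabolic stability, read by LC-MS, with NADPH named in the record, with a stated time of 60 min, tested at 1 uM, in the absence of a further agent (a lower number here means that less of the compound is left, a higher number that more of the compound is left), follow
- compound 1 `COc1ccc(-c2c(C)nc3c(N4CC[C@@H](NC(C)=O)C4)cc(C)nn23)cc1OC` gives > 95% as a limit
- compound 2 `COc1ccc(-c2c(C)nc3c(N4CC[C@@H](NC(C)=O)C4)cc(C)nn23)cc1F` gives > 95% as a limit
- compound 3 `COc1ccc(-c2c(C)nc3c(N4CC[C@@H](NC(C)=O)C4)cc(C)nn23)cn1` gives > 95% as a limit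

Compound 3 stands at > 95% and this is a limit, not a number. The series offers only the limit of > 95% in this assay, at which 3 of the 3 values shown sit, and no rank can be given to compound 3.

Compound 4 `CC(=O)N[C@@H]1CCN(c2cc(C)nn3c(-c4cccs4)c(C)nc23)C1` carries thiophen-2-yl in place of 6-methoxypyridin-3-yl on an aromatic carbon, a change counted as thiophen-2-yl in place of 6-methoxypyridin-3-yl on an aromatic carbon in full.

The nearest measured changes are a step that the two limits leave unreadable from compound 1 to compound 3 and a step that the two limits leave unreadable from compound 2 to compound 3 with a step that the two limits leave unreadable from compound 1 to compound 2 as a further case. None of them has a readable size, and no five-membered aromatic ring has been measured at this carbon.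

Since compound 1, compound 2 and compound 3 all sit at the limit of > 95% in this assay, at which 3 of the 3 values shown sit, little or no fall is expected for compound 4 in this assay with the direction, if any, downward. The estimated step is a number at least 5 percentage points lower from compound 3 to compound 4 (that floor lies within the scatter) and a further report at the limit remains possible. For compound 4 the estimate is 90% with an expected range from 65% to 100% in this assay.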

Compound 4, percent of the compound remaining: > 95%
Compound 4: a limit, no number (the forecaster's own chance of this, stated with the estimate: 50%); at least 5 percentage points between middle value and limit.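

In this assay, within the data shown here, compound 4 gives > 95%, which is a limit and not a number, so no step from compound 1, compound 2 or compound 3 to compound 4 can be read. The compounds shown leave open how far their stability differs and whether any group at this carbon lowers the percent remaining.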